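Compound 3: chloro in place of trifluoromethyl

A few compounds are considered here, and "the series" means these few. Any claim that something is new, unique, unknown or untested is made for them only; others in the source may bear on it.

Measured so far:
compound 1 `COc1cc(-c2nn(-c3cccc(NC(=O)c4cccc(C(F)(F)F)c4)c3)cc2-c2ccncc2)ccc1Cl`; in a functional assay on HCC 2998 cells (Homo sapiens) for inhibition, read by sulforhodamine B assay, with a stated time of 48 h (a lower number here means a stronger inhibitor of growth, a higher number a weaker inhibitor of growth), compound 1 gives 17600 nM
compound 2 `COc1cc(-c2nn(-c3cccc(NC(=O)Nc4ccc(Cl)c(C(F)(F)F)c4)c3)cc2-c2ccncc2)ccc1Cl`; in this assay compound 2 gives 7300 nM

Compound 2 holds the lower of the two numbers. For the measured compounds named here, the single measured step is a 2.4-fold lower number from compound 1 to compound 2 (0.38 log units; beyond the scatter), which put (4-chloro-3-(trifluoromethyl)phenyl)amino in place of 3-(trifluoromethyl)phenyl on a carbonyl carbon. Compound 3 `COc1cc(-c2nn(-c3cccc(NC(=O)Nc4ccc(Cl)c(Cl)c4)c3)cc2-c2ccncc2)ccc1Cl` keeps that arrangement and differs from compound 2 only in this: chloro in place of trifluoromethyl on an aromatic carbon. Cut one bond further out, the difference reads 4-chloro-3-(trifluoromethyl)phenyl to 3,4-dichlorophenyl. Going by the values given here, no measured pair isolates this exchange; the step from compound 1 to compound 2 changes linkage and aryl together and bears on it only loosely. With nothing to weigh one way or the other, no step beyond the scatter is expected in this assay; the expected step is a 1.1-fold higher number from compound 2 to compound 3 (0.04 log units; within the scatter). Compound 3 is therefore estimated at 8000 nM, within a range of 3500 nM to 18000 nM.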

Compound 3, concentration for total growth inhibition: 6200 nM
Compound 3: middle estimate off by 1.3-fold (0.11 log units), on the high side; low and high end bracket the measured number.
By their numbers in this assay, from the lowest: compounds 3 and 2 (each within the scatter of the next); then compound 1.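

In this assay, the exchange at this aromatic carbon, ortho to a chloro group, gives a 1.2-fold lower number from compound 2 to compound 3 (0.07 log units; within the scatter), so trifluoromethyl with its 4 heavy atoms and chloro with its 1 heavy atom are not separated here. The change on the carbonyl carbon to (3,4-dichlorophenyl)amino gives a 2.8-fold lower number from compound 1 to compound 3 (0.45 log units; beyond the scatter), which shows that a lower number than that of compound 1 does not require trifluoromethyl on the aryl ring. No measurement on hand accounts for either step.

From the compounds shown here alone, an amine, a methoxy or a carboxylic acid at this aromatic carbon remains open. Also open, going by these compounds, is whether the linkage or the aryl substitution carries the step away from compound 1, since both differ at once in each comparison with it.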